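Methyl in place of hydrogen on an aromatic oxygen

The source may hold more compounds than are shown below. What is called first, only, known or untested is meant among the compounds shown, and "the series" means these compounds.

Compound 1 `O=C1OC[C@H](Cc2ccccc2)[C@H]1Cc1ccccc1O`: 83000 nM
Compound 2 `COc1ccccc1C[C@H]1C(=O)OC[C@@H]1Cc1ccccc1`: 79000 nM
Compound 3 `COc1cc(C[C@H]2C(=O)OC[C@@H]2Cc2ccccc2)ccc1O`: 93000 nM

All three were measured in a functional assay on HL-60 cells (Homo sapiens) for cytotoxicity, read by WST assay, with a stated time of 48 h; a lower number here means that less compound is needed, a higher number that more compound is needed for the effect. Compound 1 and compound 2 differ by one change, (methyl in place of hydrogen on an oxygen on an aromatic ring), and that change gave a 1.1-fold lower number from compound 1 to compound 2 (0.02 log units; within the scatter). Compound 3 carries a different core; the difference between the core of compound 1 and the core of compound 3 is not broken down here. Compound 4 `COc1ccc(C[C@H]2C(=O)OC[C@@H]2Cc2ccccc2)cc1OC` is compound 3 with the same change applied: methyl in place of hydrogen on an oxygen on an aromatic ring. The two places are described in the same words, so this is the same change on another core. Because the earlier step of a 1.1-fold lower number from compound 1 to compound 2 (0.02 log units; within the scatter) stayed within the scatter, a similarly small step is expected, a 1.1-fold lower number from compound 3 to compound 4 (0.04 log units; within the scatter). Compound 4 is therefore estimated at 85000 nM in this assay, with a likely range from 40000 nM to 180000 nM.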

Compound 4, half-maximal effective concentration: > 100000 nM
Compound 4 gave a limit, no number (the forecaster's own chance of this, stated with the estimate: 20%); at least 1.1-fold (0.07 log units) between middle value and limit.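

In this assay compound 4 gives > 100000 nM, which is a limit of the assay and not a number. On these data alone, the step therefore reads an at least 1.0-fold higher number from compound 3 to compound 4 (0.03 log units; that floor lies within the scatter), and this is only a floor, so the true size of the step on this core stays unknown. Setting it beside the step on the other core shows neither that the change from hydroxy to methoxy carries over in the same way nor that it does not: the same change on two cores in this assay, a 1.1-fold lower number (0.02 log units; within the scatter) from compound 1 to compound 2 and an at least 1.0-fold higher number (0.03 log units; that floor lies within the scatter) from compound 3 to compound 4; the limit leaves it open whether they differ

The compounds shown leave open what a longer chain on that oxygen, such as ethyl, would do in this assay. They also leave open what an amine or a carboxylic acid in place of the hydroxy would do there.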